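The source may report more compounds than this note shows. Statements on the series, on what has been measured and on what is new or still open speak of the compounds shown alone.

Measured in a functional assay on NCI-H460 cells (Homo sapiens) for cytotoxicity, read by sulforhodamine B assay; a lower number here means a stronger inhibitor of growth, a higher number a weaker inhibitor of growth:
- compound 1 `CC1=CC[C@@H]([C@@](C)(O)CCCC(C)(C)NC=S)CC1`: 9250 nM
- compound 2 `CC1=CC[C@@H]([C@@](C)(O)CCCC(C)(C)NC(=S)NN)CC1`: 12800 nM
- compound 3 `COc1ccc(/C=N\NC(=S)NC(C)(C)CCC[C@](C)(O)[C@@H]2CC=C(C)CC2)cc1`: 5100 nM

Compound 3 and compound 1 lie within the scatter of each other, while compound 3 lies below compound 2 by more than the scatter.

The next compound is compound 4 `CC1=CC[C@@H]([C@@](C)(O)CCCC(C)(C)NC(=S)N/N=C\c2cccc([N+](=O)[O-])c2)CC1`. It differs from compound 3 at one place: 3-nitrophenyl in place of 4-methoxyphenyl on a carbon with a double bond to nitrogen. In words, 3-nitrophenyl stands in place of 4-methoxyphenyl on a carbon with a double bond to nitrogen.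

Among the compounds with values here, two measured steps bear on this only indirectly. The first is a 1.4-fold higher number from compound 1 to compound 2 (0.14 log units; within the scatter). Within the data shown here, the second, the only one involving an aromatic ring, is a 2.5-fold lower number from compound 2 to compound 3 (0.40 log units; beyond the scatter). Among the measured compounds shown here, no measured pair exchanges one aromatic group for another, so the size of this exchange in this assay has no direct precedent. Given the modest size of the step to compound 3, a 2.5-fold lower number from compound 2 to compound 3 (0.40 log units; beyond the scatter), a large shift is not expected, and no direction is favoured. The expected change is a 1.1-fold higher number from compound 3 to compound 4 (0.03 log units; within the scatter), which would not go beyond the scatter. The estimated value for compound 4 is 5500 nM, with an expected range of 2200 nM to 13000 nM.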

Compound 4, concentration for 50% growth inhibition: 8290 nM
Beside the measured number, compound 4's estimate is 1.5-fold (0.18 log units) below it; the range from low to high includes it.
By their numbers in this assay, from the lowest: compounds 3, 4, 1 and 2 (each within the scatter of the next, the first and the last beyond it).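

In this assay, within the data shown here, the exchange of 4-methoxyphenyl for 3-nitrophenyl on a carbon with a double bond to nitrogen gives a 1.6-fold higher number from compound 3 to compound 4 (0.21 log units; within the scatter) and is the first measured swap of one aromatic group for another at this place. The entering group brings a nitrogen and a second hydrogen-bond acceptor by count, and the ring stays a six-membered aromatic ring of carbon only, yet the two compounds cannot be separated in this read-out, so at this place these two aromatic groups are interchangeable within the scatter. No measurement at hand bears on why the two groups read alike.

From the compounds shown here alone, with only these two aromatic groups compared, it remains open whether any group at this place can move the number beyond the scatter in either direction, for instance a phenyl carrying a carboxylic acid or a dimethylamino group, or a saturated cyclohexyl ring in place of the aromatic ring. Also open is whether 3-nitrophenyl and 4-methoxyphenyl would stay as close on other cell lines, since the compounds shown are read on one line only.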